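Compound 3 at the high end of the series

The compounds below may be only part of what the source reports. "The series", "measured", "known", "first", "only" and "open" are said of these compounds alone.

In an ADME assay on HepG2 2.2.15 cells (Homo sapiens) for cytotoxicity, read by MTT assay (a lower number here means that less compound is tolerated, a higher number that more compound is tolerated), compound 1 `C=C1CC[C@@H]2[C@](C)(COC(=O)c3cc(=O)c4ccccc4o3)[C@H](O)CC[C@@]2(C)[C@@H]1/C=C/C1=CCOC1=O` gives 171000 nM, compound 2 `C=C1CC[C@H]2[C@@](C)(CCC(=O)[C@@]2(C)C=O)[C@@H]1/C=C/C1=CCOC1=O` gives 275000 nM and compound 3 `C=C1CC[C@H]2[C@@](C)(CCC(=O)[C@@]2(C)C=O)[C@@H]1C/C=C1\C=COC1=O` gives 964000 nM, the highest of the three numbers. Compound 4 `C=C1CC[C@H]2[C@@](C)(CCC(=O)[C@@]2(C)C=O)[C@@H]1C/C=C1/C(=O)OC[C@H]1O` is still unmeasured. Its change from compound 3 is a group of 8 heavy atoms (5 carbon, 3 oxygen; one five-membered non-aromatic ring with 1 hetero atom) in place of a group of 7 heavy atoms (5 carbon, 2 oxygen; one five-membered non-aromatic ring with 1 hetero atom), on a saturated chain carbon bound to a saturated ring carbon, and the entering group has 1 defined stereocentre. One measured step alters the same end of the molecule: a 3.5-fold higher number from compound 2 to compound 3 (0.54 log units; beyond the scatter), which is modest. That single step gives little guidance on direction, but compound 3 already has the highest number, so the expected move is downward and of similar modest size. The expected step is a 1.9-fold lower number from compound 3 to compound 4 (0.29 log units; within the scatter). For compound 4 the estimated value is 500000 nM, with an expected range of 170000 nM to 1400000 nM.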

Compound 4, half-maximal cytotoxic concentration: 155000 nM
The estimate for compound 4 lay 3.2-fold (0.51 log units) above the measured number; measured number below the stated range.
By their numbers in this assay, from the lowest: compounds 4, 1 and 2 (each within the scatter of the next); then compound 3.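

In this assay, within the data shown here, the side-chain ring on this saturated chain carbon bound to a saturated ring carbon can also lower the number: a 6.2-fold lower number from compound 3 to compound 4 (0.79 log units; beyond the scatter), whereas the only earlier step here, a 3.5-fold higher number from compound 2 to compound 3 (0.54 log units; beyond the scatter), raised it. The entering group differs from the leaving one in donor count, acceptor count, double bonds and a defined stereocentre, and this single step cannot separate these. Nothing available explains the drop.

Open, going by these compounds, is whether the same ring carrying an amine or a methoxy group would give a similar number. Also open, on these data alone, is how the opposite configuration at the stereocentre would read.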